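Hydroxy for ethyl in a dibromophenyl hydrazide series

The source may report more compounds than this note shows. Statements on the series, on what has been measured and on what is new or still open speak of the compounds shown alone.

Measured compounds:
compound 1, `CCc1ccc(C(=O)NNc2c(Br)cccc2Br)cc1` — > 100000 nM
compound 2, `CCc1ccc(C(=O)NNc2c(Br)cc(Br)cc2Br)cc1` — > 100000 nM
compound 3, `CCOc1ccc(C(=O)NNc2ccc(Br)cc2)cc1` — > 100000 nM

In a toxicity assay on MDCK cells (Canis lupus familiaris) for cytotoxicity, read by CCK-8 assay, with a stated time of 48 h (on this read-out lower numbers stand for higher toxicity in this test and higher numbers for lower toxicity in this test), compound 1 gives only a limit, > 100000 nM. Compound 2 likewise gives only a limit in this assay, > 100000 nM. Compound 3 too sits at a limit in this assay, > 100000 nM. Among the measured compounds shown here, the one measured step, from compound 1 to compound 2, is a step that the two limits leave unreadable from compound 1 to compound 2, and its size cannot be read because both ends sit at the limit (the limit of > 100000 nM in this assay, at which 3 of the 3 values shown sit).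

Compound 4, `O=C(NNc1c(Br)cccc1Br)c1ccc(O)cc1`, differs from compound 1 by hydroxy in place of ethyl on an aromatic carbon. For the measured compounds named here, no measured step concerns a hydroxy group or the removal of an ethyl group, so the only guide is that all three values shown sit at the same limit. Compound 4 is therefore expected to remain at or near that limit, a step that the limit leaves unreadable from compound 1 to compound 4 being no more than a guess. The estimate for compound 4 in this assay is 150000 nM, with a range from 50000 nM to 500000 nM.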

Compound 4, half-maximal cytotoxic concentration: > 100000 nM
Compound 4: a limit, no number (the forecaster's own chance of this, stated with the estimate: 85%); the middle value is on the limit's open side.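

No step can be read from compound 1 to compound 4 in this assay, as both values are limits and not numbers: the limit of > 100000 nM in this assay, at which 4 of the 4 values shown sit.

The compounds shown leave open whether hydroxy in place of ethyl on an aromatic carbon changes the half-maximal cytotoxic concentration at all.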